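From compound 1 to compound 3: losing trifluoromethyl

The source may report more compounds than this note shows. Statements on the series, on what has been measured and on what is new or still open speak of the compounds shown alone.

Compound 1 `O=c1nc2ccccn2cc1Cc1ccc(F)cc1C(F)(F)F` gives 804000 nM
Compound 2 `O=c1nc2ccc(Br)cn2cc1Cc1ccccc1` gives the limit > 1000000 nM

For the measured compounds named here, in a functional assay on HepG2 cells (Homo sapiens) for cytotoxicity, read by MTT assay, with a stated time of 24 h (a lower number here means a stronger inhibitor, a higher number a weaker inhibitor), compound 1 gives 804000 nM as the only actual number. Compound 2 is known only by a limit. Compound 3 `O=c1nc2ccccn2cc1Cc1ccc(F)cc1` carries hydrogen in place of trifluoromethyl on an aromatic carbon and otherwise keeps the core of compound 1. Going by the values given here, no measured pair shows such a step, so the change expected in this assay stays within the scatter, if anything towards weaker inhibition. The estimate means a 1.2-fold higher number from compound 1 to compound 3 (0.07 log units; within the scatter) as the expected step. Compound 3 is estimated at 950000 nM within 450000 nM to 2000000 nM as the expected range.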

Compound 3, half-maximal inhibitory concentration: > 1000000 nM
Compound 3 was reported as a limit; the forecaster's own chance of this, stated with the estimate: 45%; middle value at least 1.0-fold (0.02 log units) away from the limit.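

In this assay compound 3 gives > 1000000 nM, which is a limit of the assay. The change from trifluoromethyl to hydrogen at this aromatic carbon amounts to an at least 1.2-fold higher number from compound 1 to compound 3 (0.09 log units; that floor lies within the scatter), so it has only a floor, and the true size of the step cannot be read. This result therefore cannot separate a real loss from no change, and it sits at the same ceiling as compound 2: the limit of > 1000000 nM in this assay, at which 2 of the 3 values shown sit.

Going by these compounds, what an amine or a carboxylic acid at this aromatic carbon would do in this assay remains open.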